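The source may hold more compounds than are shown below. What is called first, only, known or untested is meant among the compounds shown, and "the series" means these compounds.

For the measured compounds named here, compound 2, whose structure is `O=C1C(Nc2ccc(I)cc2)=CC(=O)c2ncncc21`, gives the lower of the two numbers measured so far in a functional assay on A549 cells (Homo sapiens) for cytotoxicity, read by MTT assay, with a stated time of 72 h; on this read-out lower numbers stand for stronger inhibition and higher numbers for weaker inhibition: compound 2 gives 0.27 ug/mL. Its nearest neighbour is compound 1, with the structure `O=C1C(Nc2ccc(F)cc2)=CC(=O)c2ncncc21`, and in this assay compound 1 gives 1.08 ug/mL. The two differ only in the halogen on the ring that hangs from the amine nitrogen, and that single swap gave a 4.0-fold lower number from compound 1 to compound 2 (0.60 log units; beyond the scatter).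

Compound 3, with the structure `O=C1C(Nc2ccc(Cl)cc2)=CC(=O)c2ncncc21`, has not yet been measured in this assay. It differs from compound 2 in one place: chloro in place of iodo on an aromatic carbon.

Going by the values given here, only one measured step bears on this change, the one from fluoro to iodo between compound 1 and compound 2, and it was a modest one. A chloro group has not been measured here, so the expectation rests on that single step alone and carries a wide range. Compound 3 is therefore expected to give a 2.0-fold higher number from compound 2 to compound 3 (0.31 log units; beyond the scatter) in this assay, a step that is unlikely to move far beyond the scatter in either direction. The estimate for compound 3 in this assay is 0.55 ug/mL, with a range from 0.25 ug/mL to 1.2 ug/mL.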

Compound 3, half-maximal inhibitory concentration: 0.02 ug/mL
Estimate against measurement, compound 3: 28-fold (1.44 log units) above; measured number below the stated range.
By their numbers in this assay, from the lowest: compound 3; then compound 2; then compound 1.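

Changing the halogen at this place on the ring does not move the number in one steady direction. In this assay, chloro in place of iodo gave a 14-fold lower number from compound 2 to compound 3 (1.13 log units; beyond the scatter), and chloro in place of fluoro gave a 54-fold lower number from compound 1 to compound 3 (1.73 log units; beyond the scatter), so both of these steps are large, whereas the earlier swap of fluoro for iodo was only modest. With fluoro and iodo alone, the heavier halogen seemed to give the lower number, but compound 3 goes against that reading, and no measurement at hand says why chloro stands out among these three halogens.

The compounds shown leave open whether the low number is special to chloro or would also appear with bromo, the halogen missing from this set, or with a non-halogen group such as methyl, methoxy or trifluoromethyl in the same place. They also leave open whether chloro would keep this advantage at another place on the ring, and whether a hydrogen there, with no substituent at all, would sit closer to compound 3 or to compound 1.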